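Swapping benzoyl for (piperazin-1-yl)sulfonyl on a shared core

The compounds below may be only part of what the source reports. "The series", "measured", "known", "first", "only" and "open" are said of these compounds alone.

Compound 1 `C#CCN(Cc1ccc2nc(C)nc(O)c2c1)c1ccc([N+](=O)[O-])cc1` and compound 2 `C#CCN(Cc1ccc2nc(C)nc(O)c2c1)c1ccc(C(=O)c2ccccc2)cc1` share one core and differ in a single group. In a functional assay on L1210 cells (Mus musculus) for inhibition (on this read-out higher numbers stand for weaker inhibition and lower numbers for stronger inhibition), compound 1 gives 4700 nM and compound 2 gives 7700 nM, so compound 2 stands level with compound 1 once the usual scatter of repeated measurements is allowed for. The next structure is compound 3 `C#CCN(Cc1ccc2nc(C)nc(O)c2c1)c1ccc(S(=O)(=O)N2CCNCC2)cc1`, which carries (piperazin-1-yl)sulfonyl in place of benzoyl on an aromatic carbon, para to a large group: (piperazin-1-yl)sulfonyl in place of benzoyl on an aromatic carbon. Among the compounds with values here, only one measured step bears on this change, since it concerns the same place on the molecule. Replacing nitro with benzoyl gave a 1.6-fold higher number from compound 1 to compound 2 (0.21 log units; within the scatter), so two different groups there left the number within the scatter. That single step is thin evidence, and the group entering in compound 3 has not been tested before. In this assay no change beyond the scatter is therefore expected, though with a wide margin. The expected step is a 1.2-fold lower number from compound 2 to compound 3 (0.07 log units; within the scatter). For compound 3 the estimated value is 6500 nM, with an expected range of 2000 nM to 20000 nM.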

Compound 3, half-maximal inhibitory concentration: > 50000 nM
Compound 3: a limit, no number; the forecaster's own chance of this, stated with the estimate: 10%; middle value at least 7.6-fold (0.88 log units) away from the limit.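

The wider view shows that this position does not accept every group equally. Nitro and benzoyl left the number within the scatter, but in this assay (piperazin-1-yl)sulfonyl gives an at least 6.4-fold higher number from compound 2 to compound 3 (0.81 log units; beyond the scatter) and an at least 10-fold higher number from compound 1 to compound 3 (1.02 log units; beyond the scatter). Going by these compounds, compound 3 reads > 50000 nM, which is a limit and not a number, so both steps are minimum sizes and the full size of the change is unknown: the limit of > 50000 nM in this assay, at which 1 of the 3 values shown sits. The change also replaces a six-membered aromatic ring of carbon only with a six-membered non-aromatic ring with 2 hetero atoms, and it goes from 0 hydrogen-bond donors to 1, so several features change at once.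

The compounds shown do not separate the sulfonyl link from the piperazine ring, and a piperidin-1-ylsulfonyl or methylsulfonyl group in the same place would help to tell the two apart. On these data alone, it also remains open whether other groups at this position, such as an amine or a carboxylic acid, would stay level with nitro and benzoyl or fall with (piperazin-1-yl)sulfonyl.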